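This account rests on a few compounds, and the source may have more. Where it says the series, first, only, none or still open, it means among the compounds named here.

Of the compounds shown here, three built on a shared core have been measured in a functional assay for agonist activity at growth hormone secretagogue receptor type 1 (Homo sapiens), read by FLIPR; a higher number here means that more compound is needed for the effect, a lower number that less compound is needed. Compound 1 `COc1cc2c(cc1N1C[C@@H](C)N(C)[C@@H](C)C1)N(S(=O)(=O)c1ccc3ccccc3c1)CC2` gives 39.8 nM. Compound 2 `COc1cc2c(cc1N1C[C@@H](C)N[C@@H](C)C1)N(S(=O)(=O)CCc1ccccc1Cl)CC2` gives 5.01 nM. Compound 3 `COc1cc2c(cc1N1CCN[C@H](C)C1)N(S(=O)(=O)c1ccc(-c3ccccn3)s1)CC2` gives 3.98 nM, the lowest of the three numbers; compound 2 lies within the scatter of it, whereas compound 1 stands beyond the scatter with the higher number. Going by the values given here, no pair of measured compounds differs in a single place, so no measured step isolates one change.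

Compound 4 `COc1cc2c(cc1N1CCNC(C)(C)C1)N(S(=O)(=O)c1ccc(-c3ccccn3)s1)CC2` is derived from compound 3 by one change: 3,3-dimethylpiperazin-1-yl in place of 3-methylpiperazin-1-yl on an aromatic carbon. The defined stereocentre of compound 3 is thereby lost. Among the compounds with values here, no measured pair shows what such a change does in this assay, so the expectation rests on the change itself. In this assay the change is expected to give at most a small step toward a higher number, quite possibly none beyond the scatter: a 2.0-fold higher number from compound 3 to compound 4 (0.30 log units; within the scatter). Compound 4 is therefore estimated at 8 nM, with a range from 2.5 nM to 25 nM.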

Compound 4, half-maximal effective concentration: 15.9 nM
Compound 4: middle estimate off by 2.0-fold (0.30 log units), on the low side, within the range that was stated.
By their numbers in this assay, from the lowest: compounds 3 and 2 (each within the scatter of the next); then compound 4; then compound 1.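

Going by these compounds alone, the swap of 3-methylpiperazin-1-yl for 3,3-dimethylpiperazin-1-yl is the first single change measured here, and in this assay it gives a 4.0-fold higher number from compound 3 to compound 4 (0.60 log units; beyond the scatter). This shows that the group on this aromatic carbon, ortho to a methoxy group, is not indifferent to the change, although the step is modest. The same change also removes the defined stereocentre, so the added carbon and the lost stereocentre cannot be told apart, and nothing available here accounts for the step.

The compounds shown leave open how an unsubstituted piperazin-1-yl, a 3-ethylpiperazin-1-yl or a morpholin-4-yl would read at this position, and how the opposite stereoisomer of the 3-methylpiperazin-1-yl would compare. They also leave open whether the same step would appear with a different group on the sulfonyl.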